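Trimming the Amide Tail on a Serotonin Receptor Ligand

The source may hold more compounds than are shown below. What is called first, only, known or untested is meant among the compounds shown, and "the series" means these compounds.

Compound 2 `O=C(NC[C@@H]1CCCc2cc(S(=O)(=O)c3cccc(F)c3)ccc21)[C@H]1CCCN1` gives the highest of the two numbers seen so far in an assay on isolated protein for displacement of a labelled ligand from 5-hydroxytryptamine receptor 6 (Homo sapiens) (a higher number here means a weaker inhibitor, a lower number a stronger inhibitor), at 0.631 nM, while compound 1 `O=C1CN=C(NC[C@@H]2CCCc3cc(S(=O)(=O)c4cccc(F)c4)ccc32)N1` gives 0.1 nM. Compound 3 `NC(=O)CNC[C@@H]1CCCc2cc(S(=O)(=O)c3cccc(F)c3)ccc21` differs from compound 2 by carbamoylmethyl in place of (pyrrolidin-2-yl)carbonyl on an amine nitrogen. Going by the values given here, the only measured step that bears on this change is a 6.3-fold higher number from compound 1 to compound 2 (0.80 log units; beyond the scatter), where altering the group on that same nitrogen already raised the number modestly. Cutting the group down further is expected to weaken binding again, with an expected step of a 4.8-fold higher number from compound 2 to compound 3 (0.68 log units; beyond the scatter). Compound 3 is therefore estimated at 3 nM, within a range from 0.6 nM to 15 nM.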

Compound 3, inhibition constant: 0.1 nM
Estimate against measurement, compound 3: 30-fold (1.48 log units) above, and the stated range ends above it.
By their numbers in this assay, from the lowest: compounds 1 and 3 (each within the scatter of the next); then compound 2.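

Swapping (pyrrolidin-2-yl)carbonyl for carbamoylmethyl on this amine nitrogen gives a 6.3-fold lower number from compound 2 to compound 3 (0.80 log units; beyond the scatter) in this assay, so here a smaller group with no ring binds better, not worse. The ring is not needed for a low number either, since replacing the five-membered ring group gives no change at the digits printed from compound 1 to compound 3 (within the scatter). Nothing measured here explains this result.

As far as these compounds go, how far this group can shrink or grow remains open. A carboxylic acid in place of the carbamoyl part, or a longer chain such as carbamoylethyl, would test that.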